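Compound 3 to compound 4: moving the methyl group

The source may hold more compounds than are shown below. What is called first, only, known or untested is meant among the compounds shown, and "the series" means these compounds.

Measured in a functional assay on ACHN cells (Homo sapiens) for inhibition, read by sulforhodamine B assay; on this read-out lower numbers stand for stronger inhibition of growth and higher numbers for weaker inhibition of growth:
- compound 1 `COc1ccccc1CN1CCC=C(CCC(=O)NO)C1=O`: > 10000 nM
- compound 2 `O=C(CCC1=CCCN(Cc2ccc(F)cc2)C1=O)NO`: "not determined" (no result reported)
- compound 3 `Cc1cccc(CN2CCC=C(CCC(=O)NO)C2=O)c1`: 4380 nM

Among the measured compounds shown here, compound 3 holds the only actual number in the set, at 4380 nM. Compound 1 gives > 10000 nM, which is a limit of the assay and not a number. Compound 2 has no reported result.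

Compound 4 `Cc1ccccc1CN1CCC=C(CCC(=O)NO)C1=O` differs from compound 3 as follows: 2-methylphenyl in place of 3-methylphenyl on a saturated chain carbon bound to an amide-type nitrogen in a ring. It carries 2-methylphenyl in place of 3-methylphenyl on a saturated chain carbon bound to an amide-type nitrogen in a ring. For the measured compounds named here, no measured step in the set covers this change, so no step beyond the scatter is expected in this assay. This means an expected 1.1-fold higher number from compound 3 to compound 4 (0.06 log units; within the scatter). For compound 4 the estimate is 5000 nM, with an expected range of 2000 nM to 10000 nM.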

Compound 4, concentration for 50% growth inhibition: > 10000 nM
Compound 4 ended at the assay's limit (the forecaster's own chance of this, stated with the estimate: 20%); middle value at least 2.0-fold (0.30 log units) away from the limit.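

In this assay, among the compounds shown here, moving the methyl group alone changes the result: 2-methylphenyl in place of 3-methylphenyl gives an at least 2.2-fold higher number from compound 3 to compound 4 (0.35 log units; beyond the scatter), the first readable step. Going by these compounds, compound 4 gives > 10000 nM, which is a limit of the assay and not a number, so the true size of that step stays unknown. The step between compound 1 and compound 4, methyl in place of methoxy, cannot be read: the limit of > 10000 nM in this assay, at which 2 of the 4 values shown sit.

Still open, on these data alone, is how an amine or a carboxylic acid in place of the methyl on the 3-methylphenyl group would read in this assay. As far as these compounds go, a longer chain between the ring and the amide-type nitrogen is equally open.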